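Sulfonamide amine swap in a urea activator series

The compounds below may be only part of what the source reports. "The series", "measured", "known", "first", "only" and "open" are said of these compounds alone.

Measured compounds
- compound 1, `CCOC(=O)c1ccc(NC(=O)NCc2cocn2)cc1`: 27600 nM
- compound 2, `CCOC(=O)c1ccc(NC(=O)NCc2cc[nH]n2)cc1`: 69000 nM
- compound 3, `CCN(C1CCCC1)S(=O)(=O)c1ccc(NC(=O)NCc2ccncc2)cc1`: 60 nM

The read-out throughout is an assay on isolated protein for activation of Nicotinamide phosphoribosyltransferase (Homo sapiens); a higher number here means that more compound is needed for the effect, a lower number that less compound is needed. Compound 3 stands lowest of the three numbers in this assay; compound 1 is nearest to it and compound 2 furthest, both well beyond the scatter. The one measured step among these compounds, a 2.5-fold higher number from compound 1 to compound 2 (0.40 log units; beyond the scatter), concerns the heteroaryl group on the saturated chain carbon and does not touch the sulfonyl end of the molecule.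

Compound 4, `O=C(NCc1ccncc1)Nc1ccc(S(=O)(=O)N2CC3CCC(C2)O3)cc1`, differs from compound 3 on the sulfonyl sulfur: a group of 8 heavy atoms (6 carbon, 1 nitrogen, 1 oxygen; one five-membered non-aromatic ring with 1 hetero atom, one six-membered non-aromatic ring with 2 hetero atoms) in place of a group of 8 heavy atoms (7 carbon, 1 nitrogen; one five-membered non-aromatic ring of carbon only), on a sulfonyl sulfur

Going by the values given here, no measured step bears on a change at this position, so nothing in the data shows how this assay responds to it. In the absence of a guiding step, the expectation for compound 4 is a number close to that of compound 3, with a 1.5-fold higher number from compound 3 to compound 4 (0.18 log units; within the scatter) expected to be small and of uncertain direction. Compound 4 is therefore estimated at 90 nM, within a range of 25 nM to 400 nM.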

Compound 4, half-maximal effective concentration: 279 nM
Compound 4: middle estimate off by 3.1-fold (0.49 log units), on the low side; the measured number falls inside the stated range.
By their numbers in this assay, from the lowest: compound 3; then compound 4; then compound 1; then compound 2.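

At the sulfonyl sulfur, this assay proves sensitive to the amine group: replacing cyclopentyl(ethyl)amino with the group holding one five-membered and one six-membered non-aromatic ring gives a 4.7-fold higher number from compound 3 to compound 4 (0.67 log units; beyond the scatter), a modest step. Heavy-atom count stays the same across this change, while a carbon gives way to an oxygen, a hydrogen-bond acceptor enters and the ring arrangement differs, so size by that count does not separate the two compounds. Nothing measured on these compounds accounts for the step.

Going by these compounds, the ring oxygen and the ring arrangement change together here, so their separate contributions remain open; a piperidin-1-yl or diethylamino group on the sulfonyl sulfur would help pull them apart. Also open, on these data alone, is whether the step from 1,3-oxazol-4-yl to 1H-pyrazol-3-yl carries over to compounds with a sulfonyl end.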